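Dropping the Nitro Group on the Benzoyl Arm

A few compounds are considered here, and "the series" means these few. Any claim that something is new, unique, unknown or untested is made for them only; others in the source may bear on it.

Compound 1 `CC(=O)/C(=C/c1c(-c2ccccc2)[nH]c2ccccc12)C(=O)c1ccccc1` in a functional assay on SK-MEL-28 cells (Homo sapiens) for cytotoxicity, read by MTT assay, with a stated time of 96 h (on this read-out lower numbers stand for an effect already at smaller amounts and higher numbers for an effect only at larger amounts of compound), gives > 100000 nM, a limit of the assay rather than a number.
Compound 2 `CCOC(=O)/C(=C/c1c(-c2ccccc2)[nH]c2ccccc12)C(=O)c1ccc([N+](=O)[O-])cc1` in this assay gives > 100000 nM, likewise only a limit.

Within the data shown here, compound 2 thus stands at the limit of > 100000 nM in this assay, at which 2 of the 2 values shown sit, with no measured compound below it. Compound 3 `CCOC(=O)/C(=C/c1c(-c2ccccc2)[nH]c2ccccc12)C(=O)c1ccccc1` differs from compound 2 in a single place: hydrogen in place of nitro on an aromatic carbon, in words, hydrogen in place of nitro on an aromatic carbon. Among the measured compounds shown here, no measured pair shows such a step, and both recorded values are limits, so for compound 3 the step that the limit leaves unreadable from compound 2 to compound 3 is expected to be none beyond the scatter. Compound 3 is therefore estimated at 150000 nM, within 40000 nM to 600000 nM, most likely reported again as a limit.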

Compound 3, half-maximal effective concentration: > 100000 nM
Compound 3: no number, only a limit; the forecaster's own chance of this, stated with the estimate: 85%; the middle value is on the limit's open side.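

No step can be read from compound 2 to compound 3 or from compound 1 to compound 3, because all three compounds sit at one limit: the limit of > 100000 nM in this assay, at which 3 of the 3 values shown sit. On these data alone, whether either change alters the effect in this assay stays open.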